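Working notes on compound 2 and the step to compound 3

The compounds below may be only part of what the source reports. "The series", "measured", "known", "first", "only" and "open" are said of these compounds alone.

Compound 2 `CCCCC(Sc1ccc(OCCCOc2ccc3ncccc3c2)cc1)C(=O)O` is known only as a limit. In an assay on isolated protein for inhibition of Polyunsaturated fatty acid 5-lipoxygenase (Homo sapiens), read by HPLC, with a stated time of 15 min, in the presence of a further agent that is not named here (a higher number here means a weaker inhibitor, a lower number a stronger inhibitor), compound 2 gives > 10000 nM, a limit rather than a number. Compound 1 `CCCCC(Sc1ccc(OCCCOc2ccccc2OC)cc1)C(=O)O` likewise stops at a limit. In this assay compound 1 gives > 10000 nM, a limit. The step that the two limits leave unreadable from compound 1 to compound 2 is thus unreadable, both values sitting at the limit of > 10000 nM in this assay, at which 2 of the 2 values shown sit. Compound 3 `CCCCC(Sc1ccc(OCCCOc2ccc(C)cc2)cc1)C(=O)O` differs from compound 2 by 4-methylphenyl in place of quinolin-6-yl on an oxygen on a saturated carbon. Within the data shown here, no measured step in this assay reads, so no size or direction beyond the scatter can be drawn from them. For compound 3 the expected value in this assay is 20000 nM, range 5000 nM to 100000 nM, most likely again a limit. The step that the limit leaves unreadable from compound 2 to compound 3 is estimated as no readable change.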

Compound 3, half-maximal inhibitory concentration: 5200 nM
Compound 3: the middle estimate sits 3.8-fold (0.59 log units) above what was measured, and the stated range covers the measured number.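

Of the three compounds, only compound 3 gives a number rather than a limit in this assay, so a change on the oxygen on a saturated carbon can bring this series within reading range. 4-Methylphenyl in place of quinolin-6-yl gives an at least 1.9-fold lower number from compound 2 to compound 3 (0.28 log units; that floor lies within the scatter), and 4-methylphenyl in place of 2-methoxyphenyl gives an at least 1.9-fold lower number from compound 1 to compound 3 (0.28 log units; that floor lies within the scatter). Both steps are floors only, so neither shows a change beyond the scatter: the limit of > 10000 nM in this assay, at which 2 of the 3 values shown sit.

Going by these compounds, the true size of both steps stays open. So does how an unsubstituted phenyl, or a chlorine in place of the methyl of 4-methylphenyl, would read here.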